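The compounds below may be only part of what the source reports. "The series", "measured", "known", "first", "only" and "open" are said of these compounds alone.

Measured compounds:
- compound 1, `C[C@@H](Nc1c(C(N)=O)cnc2ccc(C#N)cc12)c1ccc(Cl)cc1`, in an ADME assay on cells (Hepatocyte, Rattus norvegicus) for metabolic stability, with a stated time of 90 min (a lower number here means slower removal, a higher number faster removal of the compound), gives 41 uL/min
- compound 2, `NC(=O)c1cnc2ccc(-c3cccnc3)cc2c1SC1CCCC1`, in this assay gives 120 uL/min

Within the data shown here, of the two compounds measured so far, compound 2 stands at the higher end: its number in this assay is the larger of the pair, and the gap between compound 1 and compound 2 is wider than the usual scatter of repeated measurements, so compound 2 is removed faster in this setting.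

Compound 3, `C[C@@H](Nc1c(C(N)=O)cnc2ccc(-c3cccnc3)cc12)C1CCOCC1`, has not yet been measured. It differs from compound 2 in one place: (1-(oxan-4-yl)ethyl)amino in place of cyclopentylsulfanyl on an aromatic carbon. The new group sits on an aromatic carbon of a six-membered aromatic ring with one nitrogen, within a fused system of two rings, and it carries a hydrogen-bond donor where the departing group had none.

Among the measured compounds shown here, no step between two measured compounds shows what this exact change does, so the expectation rests on the spread between compound 1 and compound 2. Compound 1, which also carries an amino-linked group at this place, gives the lower number, so a downward step from compound 2 to compound 3 is expected, of roughly a 2.2-fold lower number from compound 2 to compound 3 (0.34 log units; beyond the scatter), likely beyond the scatter though not with certainty. On that basis, compound 3 is expected to give about 55 uL/min in this assay, within a range of 22 uL/min to 135 uL/min.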

Compound 3, intrinsic clearance in a liver preparation (reported as CLH), per the amount of preparation that the assay uses: 46 uL/min
Beside the measured number, compound 3's estimate is 1.2-fold (0.08 log units) above it; measured number inside the range.
By their numbers in this assay, from the lowest: compounds 1 and 3 (each within the scatter of the next); then compound 2.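

In this assay the exchange of cyclopentylsulfanyl for (1-(oxan-4-yl)ethyl)amino, on the aromatic carbon opposite the ring nitrogen, gives a 2.6-fold lower number from compound 2 to compound 3 (0.42 log units; beyond the scatter) with the rest of the molecule unchanged. Among these compounds, this is the first reading of a single change at this position, and it shows that the group placed here can by itself shift the clearance number by more than repeat measurements would. The two groups differ in several ways at once, in the atom joined to the aromatic carbon, the ring, the hydrogen-bond donor and the defined stereocentre, so the step belongs to the whole exchange, and no measurement shown here explains it.

It remains open which of these differences accounts for the step: a cyclopentylamino group would change the joining atom while keeping the cyclopentyl ring, and an oxan-4-ylsulfanyl group would change the ring while keeping the sulfur. As far as these compounds go, it is also open whether the same exchange would give a similar step with a group other than the pyridin-3-yl ring carried elsewhere on the shared core, such as the nitrile.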